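The source may report more compounds than this note shows. Statements on the series, on what has been measured and on what is new or still open speak of the compounds shown alone.

Compound 1 `CNC(=O)c1ccc(-c2nc(COc3cc(OC)cc4oc(-c5cn6nc(OC)sc6n5)cc34)cs2)cc1`: 0.4 nM
Compound 2 `COc1cc(OCc2csc(-c3ccc(OC)nc3)n2)c2cc(-c3cn4nc(OC)sc4n3)oc2c1`: 0.8 nM

Both compounds were tested in a functional assay on HEK293 cells for antagonist activity at proteinase-activated receptor 4 (Homo sapiens), read by FLIPR and calcium flux, with a stated time of 30 min; on this read-out higher numbers stand for weaker inhibition and lower numbers for stronger inhibition. Compound 1 gives 0.4 nM, the lower of the two numbers, but compound 2 sits within the scatter of it: the step of a 2.0-fold higher number from compound 1 to compound 2 (0.30 log units; within the scatter) is too small to count as a real difference, although it exchanges the whole outer aryl group.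

Compound 3 `COc1cc(OCc2csc(-c3ccccc3)n2)c2cc(-c3cn4nc(OC)sc4n3)oc2c1` has not yet been measured. It differs from compound 1 by hydrogen in place of methylcarbamoyl on an aromatic carbon. Among the measured compounds shown here, the only measured step that bears on this position is a 2.0-fold higher number from compound 1 to compound 2 (0.30 log units; within the scatter), which replaced the entire outer ring including the methylcarbamoyl and left the number essentially unchanged. That suggests this end of the molecule tolerates variation, though losing the methylcarbamoyl with its hydrogen-bond donor and acceptor might still cost a little. Compound 3 is therefore expected to land near compound 1, with a modest rise, a 3.8-fold higher number from compound 1 to compound 3 (0.57 log units; beyond the scatter), at most: an estimated 1.5 nM, in the range 0.4 nM to 6 nM.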

Compound 3, half-maximal inhibitory concentration: 0.3 nM
Beside the measured number, compound 3's estimate is 5.0-fold (0.70 log units) above it, and the stated range ends above it.
By their numbers in this assay, from the lowest: compounds 3, 1 and 2 (each within the scatter of the next, the first and the last beyond it).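

Compound 3 shows that the methylcarbamoyl group itself is not needed in this assay: taking it away alone, which leaves a plain phenyl, gives a 1.3-fold lower number from compound 1 to compound 3 (0.12 log units; within the scatter) and so no real difference. The earlier step replaced the whole outer ring at once, so it could not separate this group from the ring that carries it, and the new step of a 2.7-fold lower number from compound 2 to compound 3 (0.43 log units; beyond the scatter) adds a modest difference between phenyl and 6-methoxypyridin-3-yl. Nothing available explains why these numbers fall as they do.

Still open, on these data alone, is whether this carbon of the phenyl ring accepts other groups, such as a carboxylic acid, an amine or a longer chain, without a larger change in the number. As far as these compounds go, whether phenyl can give way to a saturated ring such as cyclohexyl is also open.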